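The source may hold more compounds than are shown below. What is called first, only, known or untested is meant among the compounds shown, and "the series" means these compounds.

Working notes on the series. In a functional assay on the whole organism with Mus musculus as the target, with a stated time of 20 min (on this read-out higher numbers stand for an effect only at larger amounts of compound and lower numbers for an effect already at smaller amounts), compound 1 `CC(C)S(=O)(=O)N1CCN2C(=O)CCC2C1` gives 10 mg/kg, compound 3 `CC(C)S(=O)(=O)Nc1ccc(N(C)S(=O)(=O)c2ccc(F)cc2)cc1` gives 1 mg/kg, and compound 2 `CCC(=O)N[C@H]1CC[C@H](NS(=O)(=O)c2ccc(F)cc2)CC1` gives 0.1 mg/kg, the lowest of the three numbers; the nearest, compound 3, stands beyond the scatter above it, and compound 1 further still. The next compound, compound 4 `CCC(=O)N[C@H]1CC[C@@H](NS(=O)(=O)c2ccc(F)cc2)CC1`, is not yet measured in this assay. It differs from compound 2 only as follows: the two compounds have the same atoms and bonds and differ only in configuration as drawn: 2 of 2 stereo elements differ (all stereocentres are inverted: mirror images); a stereocentre at a saturated ring carbon is drawn r in compound 2 and s in compound 4; a stereocentre at a saturated ring carbon is drawn r in compound 2 and s in compound 4. Among the measured compounds shown here, no pair of measured compounds in this set shows such a change, so there is no measured step to lean on. For compound 4 the estimated step of a 10-fold higher number from compound 2 to compound 4 (1.00 log units; beyond the scatter) in this assay is toward a higher number, beyond the scatter. Compound 4 is expected to give about 1 mg/kg, within 0.2 mg/kg to 10 mg/kg.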

Compound 4, minimum effective dose: 10 mg/kg
Compound 4: the middle estimate sits 10-fold (1.00 log units) below what was measured; the measured number falls inside the stated range.
By their numbers in this assay, from the lowest: compound 2; then compound 3; then compounds 1 and 4 (each within the scatter of the next).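

In this assay, among the compounds shown here, inverting both stereocentres at the saturated ring carbons gives a 100-fold higher number from compound 2 to compound 4 (2.00 log units; beyond the scatter), the first measured step and a large one. No atom or bond enters or leaves, so the dose read-out here depends strongly on configuration as drawn. The step can be assigned to configuration alone on this ground: the fact that compounds 2 and 4 differ only in the configuration as drawn.

As far as these compounds go, whether inverting only one stereocentre would carry the same step remains open. So does whether this dependence on configuration would hold with a longer chain on the carbonyl, or with an amine in its place.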